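This account rests on a few compounds, and the source may have more. Where it says the series, first, only, none or still open, it means among the compounds named here.

Of the compounds shown here, three sharing one core have been tested in a functional assay on HepG2 cells (Homo sapiens) for cytotoxicity, with a stated time of 24 h; a lower number here means a stronger inhibitor, a higher number a weaker inhibitor. Compound 1 `O=C(N/N=C/c1cc(I)cc(I)c1O)c1ccc(I)cc1` gives 31800 nM in this assay. Compound 2 `O=C(N/N=C/c1cc(I)c(O)c(I)c1)c1ccc(O)cc1` gives 110000 nM in this assay. Compound 3 `O=C(NNC(=O)c1cc(I)cc(I)c1O)c1ccccc1` gives 98000 nM in this assay, the second highest of the three numbers; its nearest neighbour is compound 2, whose value lies within the scatter of it, while compound 1 stands beyond the scatter with a lower number.

The next compound, compound 4 `O=C(NNC(=O)c1cc(I)cc(I)c1O)c1ccc([N+](=O)[O-])cc1`, has not yet been measured in this assay. It differs from compound 3 in one place: nitro in place of hydrogen on an aromatic carbon.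

Going by the values given here, no measured pair shows this exact change, so its effect here is not known. Because compound 1 gives 31800 nM with a substituent at the same place, a modest move toward a lower number is expected, and the step of a 1.6-fold lower number from compound 3 to compound 4 (0.21 log units; within the scatter) is estimated to stay close to the scatter. Compound 4 is therefore expected to give about 60000 nM in this assay, within a range from 20000 nM to 150000 nM.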

Compound 4, half-maximal inhibitory concentration: 159000 nM
Estimate against measurement, compound 4: 2.7-fold (0.42 log units) below; measured number outside the range, above it.
By their numbers in this assay, from the lowest: compound 1; then compounds 3, 2 and 4 (each within the scatter of the next).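

The step of a 1.6-fold higher number from compound 3 to compound 4 (0.21 log units; within the scatter) in this assay comes from nitro in place of hydrogen on an aromatic carbon, para to a large group. This place on the ring therefore takes on a group of three heavy atoms with no net charge, and the result cannot be told apart from the scatter, so compound 3 and compound 4 read as equal here. Nothing measured on these compounds offers an explanation for this result.

From the compounds shown here alone, whether any group at this place can move the number beyond the scatter remains open, for example an amine, a carboxylic acid or a longer chain. Going by these compounds alone, with only this one pair to go on, it is also unknown whether nitro would behave the same way on other compounds.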